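Swapping a cyclic amine for an open one in compound 4

A few compounds are considered here, and "the series" means these few. Any claim that something is new, unique, unknown or untested is made for them only; others in the source may bear on it.

Measured compounds:
- compound 1 `COc1ccc(-c2c(C)nn3c(N4CCCC4)nc(C)nc23)c(C)c1`: 80.7 nM
- compound 2 `CCCCN(CC)c1nc(C)nc2c(-c3c(C)cc(OC)cc3OC)c(C)nn12`: 1.72 nM
- compound 3 `CCCCN(CC)c1nc(C)nc2c(-c3c(C)cc(OC)cc3C)c(C)nn12`: 4.22 nM

In an assay on cell membranes for displacement of a labelled ligand from corticotropin-releasing factor receptor 1 (Rattus norvegicus) (a higher number here means a weaker inhibitor, a lower number a stronger inhibitor), compound 1 gives 80.7 nM, the highest of the three numbers; compound 3 lies nearest and compound 2 furthest, both well beyond the scatter. Within the data shown here, the one single-point step in the set, a 2.5-fold higher number from compound 2 to compound 3 (0.39 log units; beyond the scatter), concerns the aryl group and is modest.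

Compound 4 `COc1ccc(-c2c(C)nn3c(N(CCC#N)C4CC4)nc(C)nc23)c(C)c1` arises from compound 1 by (2-cyanoethyl)(cyclopropyl)amino in place of pyrrolidin-1-yl on an aromatic carbon. Among the measured compounds shown here, no measured pair isolates this change. Compounds 2 and 3 carry an open-chain dialkylamino group at the same place, and both give low numbers, yet they also differ from compound 1 in the aryl group, so their values bear on the expectation only loosely. On that basis a lower number is expected for compound 4, with a step of about a 5.4-fold lower number from compound 1 to compound 4 (0.73 log units; beyond the scatter) in this assay. The estimate for compound 4 is 15 nM, within 4 nM to 60 nM.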

Compound 4, half-maximal inhibitory concentration: 1.88 nM
Estimate against measurement, compound 4: 8.0-fold (0.90 log units) above; measured number outside the range, below it.
By their numbers in this assay, from the lowest: compounds 2 and 4 (each within the scatter of the next); then compound 3; then compound 1.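

On the core of compound 1, with the aryl group unchanged, this assay gives a 43-fold lower number from compound 1 to compound 4 (1.63 log units; beyond the scatter) for (2-cyanoethyl)(cyclopropyl)amino in place of pyrrolidin-1-yl, so a change at this aromatic carbon between two ring nitrogen atoms can move the number by a large step on its own. Among these compounds, the only single-place step among the earlier compounds, a 2.5-fold higher number from compound 2 to compound 3 (0.39 log units; beyond the scatter), concerned the aryl group and was modest, so it showed nothing about this position. No measurement shown here accounts for the size of the new step.

The nitrile and the cyclopropyl ring enter together, so the compounds shown do not tell how much of the step belongs to either one. On these data alone, a (2-cyanoethyl)propylamino group, with a propyl chain in place of the cyclopropyl ring, would separate the two, and it also remains open how a piperidine ring at this position would compare with the pyrrolidine of compound 1.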